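This account rests on a few compounds, and the source may have more. Where it says the series, first, only, none or still open, it means among the compounds named here.

Compound 1 `C#Cc1cccc(Nc2ncnc3cc(OC)c(OCCCCC(=O)Nc4ccc(S(N)(=O)=O)cc4)cc23)c1` gives 18800 nM in a functional assay on NCI-H1975 cells (Homo sapiens) for antiproliferative activity, read by MTT assay, with a stated time of 72 h (a higher number here means a weaker inhibitor, a lower number a stronger inhibitor), which places it second highest of the three numbers in hand. Compound 2 `COc1cc2ncnc(Nc3ccc(Cl)cc3)c2cc1OCCCCC(=O)Nc1ccc(S(N)(=O)=O)cc1` carries 4-chlorophenyl in place of 3-ethynylphenyl on the nitrogen on the aromatic ring and gives 31800 nM in this assay. The step is a 1.7-fold higher number from compound 1 to compound 2 (0.23 log units; within the scatter). Compound 3 `COc1ccccc1Nc1ncnc2cc(OC)c(OCCCCC(=O)Nc3ccc(S(N)(=O)=O)cc3)cc12` carries 2-methoxyphenyl at that nitrogen and gives 8030 nM in this assay. The steps are a 2.3-fold lower number from compound 1 to compound 3 (0.37 log units; beyond the scatter) and a 4.0-fold lower number from compound 2 to compound 3 (0.60 log units; beyond the scatter), so compound 3 gives the lowest number of the three, and the group on the anilino nitrogen moves this assay only modestly across the set.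

Compound 4 `COc1cc2ncnc(Nc3ccccc3)c2cc1OCCCCC(=O)Nc1ccc(S(N)(=O)=O)cc1` is the unmeasured member. Relative to compound 1 it shows (hydrogen in place of ethynyl on an aromatic carbon). Among the measured compounds shown here, no measured pair removes the ethynyl alone, so the only guides are the three swaps of the group on the anilino nitrogen, none of which moved this assay by more than a modest step. Loss of the ethynyl is therefore expected to give at most a small step in this assay, if anything toward a higher number. The expected step is a 1.4-fold higher number from compound 1 to compound 4 (0.14 log units; within the scatter). Compound 4 is accordingly estimated at 26000 nM in this assay, with a range of 10000 nM to 65000 nM.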

Compound 4, half-maximal inhibitory concentration: 14100 nM
For compound 4 the middle estimate is 1.8-fold (0.27 log units) above the measured one, and the stated range covers the measured number.
By their numbers in this assay, from the lowest: compounds 3, 4, 1 and 2 (each within the scatter of the next, the first and the last beyond it).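

Among the compounds shown here, the bare anilino group of the unsubstituted compound gives this position a reference point in this assay: hydrogen in place of ethynyl reads as a 1.3-fold lower number from compound 1 to compound 4 (0.12 log units; within the scatter) and hydrogen in place of methoxy as a 1.8-fold higher number from compound 3 to compound 4 (0.24 log units; within the scatter) and so separates neither group from hydrogen, whereas hydrogen in place of chloro reads as a 2.3-fold lower number from compound 2 to compound 4 (0.35 log units; beyond the scatter) and is the only one of these steps beyond the scatter. Among the groups shown, then, only chloro can be told apart from hydrogen, and only by a modest step, while ethynyl and methoxy cannot; the three groups also sit at different places on the ring, so the effect of the group and that of its place remain tangled. No supporting measurement accompanies these values, and the steps remain without an explanation.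

From the compounds shown here alone, whether an amine or a carboxylic acid on this ring, or a longer chain in place of the ethynyl, would give a step larger than these remains open. The remainder of the structure is shared by all four compounds, so these data do not show how much it contributes to the numbers.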